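The source may hold more compounds than are shown below. What is called first, only, known or untested is meant among the compounds shown, and "the series" means these compounds.

Measured compounds in a functional assay on HOP-62 cells (Homo sapiens) for cytotoxicity, read by sulforhodamine B assay, with a stated time of 48 h, tested at 0.01 uM; a lower number here means a stronger effect, a higher number a weaker effect of the compound at the concentration tested:
Compound 1 `COc1ccc(-c2cc(/C=C/C(=O)c3ccc(N)cc3)[nH]n2)cc1`: 107%
Compound 2 `COc1cc(-c2cc(/C=C/C(=O)c3ccc(N)cc3)[nH]n2)cc(OC)c1OC`: 83%
Compound 3 `COc1cc(-c2cc(/C=C/C(=O)c3ccc(F)c(F)c3)[nH]n2)cc(OC)c1OC`: 100%

Compound 2 holds the lowest of the three numbers in this assay; compound 3 lies nearest, compound 1 furthest, both beyond the scatter. Compound 4 `COc1ccc(-c2cc(/C=C/C(=O)c3ccc(N)cc3)[nH]n2)cc1OC` differs from compound 2 in one place: hydrogen in place of methoxy on an aromatic carbon. Going by the values given here, no measured step covers this exact change. Among the compounds with values here, the only step on record, a number 17 percentage points higher from compound 2 to compound 3 (beyond the scatter), alters the other end of the molecule and so bears little on it. Compound 1, carrying one methoxy, and compound 2, carrying three, show values whose gap suggests that fewer methoxy groups go with a higher number. Compound 4 is therefore expected to sit between them, with a step of a number 12 percentage points higher from compound 2 to compound 4 (beyond the scatter), giving an estimate of 95% within 80% to 110%.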

Compound 4, a percentage reported as activity, at one concentration (the size of the read-out at that concentration, not a potency): 83%
For compound 4 the middle estimate is 12 percentage points above the measured one; the range from low to high includes it.
By their numbers in this assay, from the lowest: compounds 2 and 4 (each within the scatter of the next); then compounds 3 and 1 (each within the scatter of the next).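

In this assay, taking the methoxy off this aromatic carbon, ortho to a methoxy group, is a silent change, with no change at the digits printed from compound 2 to compound 4 (within the scatter) as its step. The drop in the number comes instead with the other change, the methoxy in place of hydrogen, where a number 24 percentage points lower from compound 1 to compound 4 (beyond the scatter) is beyond the scatter. Nothing on record explains why the two changes differ. Still open, on these data alone, is whether a hydroxy group or a chlorine atom on this carbon would leave the number as unchanged, and whether the silent step also holds with the 3,4-difluorophenyl group of compound 3.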